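The source may report more compounds than this note shows. Statements on the series, on what has been measured and on what is new or still open speak of the compounds shown alone.

Of the compounds shown here, three have been measured for cytotoxicity in an ADME assay on HCT-116 cells (Homo sapiens) for cytotoxicity, read by CellTiter-Glo, with a stated time of 72 h; on this read-out higher numbers stand for weaker inhibition and lower numbers for stronger inhibition. Compound 1 `Cc1cc(C)c(S(=O)(=O)N2CCN(C3CN4CCC3CC4)CC2)c(C)c1` gives > 5000 nM, which is a limit of the assay rather than a number. Compound 2 `CC1CCN(C2CCN(S(=O)(=O)c3cn(C)c(=O)n(C)c3=O)CC2)CC1` gives > 10000 nM, also a limit. Compound 3 `Cc1cc(C)c(S(=O)(=O)N2CCC(c3ccccc3)CC2)c(C)c1` gives > 5000 nM, again a limit. Compound 3 therefore stands where most of the shown values stand, at the limit of > 5000 nM in this assay, at which 2 of the 3 values shown sit, while the remaining value sits at the limit of > 10000 nM in this assay, at which 1 of the 3 values shown sits. Because none of the three values is a number, no change within or beyond the scatter can be read between any pair of them.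

Compound 4 `Cc1cc(C)c(S(=O)(=O)N2CCC(N3CCC(O)CC3)CC2)c(C)c1` has not yet been measured. It differs from compound 3 in one place: 4-hydroxypiperidin-1-yl in place of phenyl on a saturated ring carbon. Because compound 3 gives only the limit > 5000 nM, the step expected is a step that the limit leaves unreadable from compound 3 to compound 4, nothing beyond the scatter. Compound 4 is accordingly expected to give about 20000 nM, within a range from 5000 nM to 80000 nM, and most probably to be reported once more as a limit rather than a number.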

Compound 4, half-maximal inhibitory concentration: > 5000 nM
Compound 4: only a limit was reported; the forecaster's own chance of this, stated with the estimate: 85%; the middle value does not contradict the limit.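

Compound 3 and compound 4 are both reported only as limits, not as numbers, so no step can be read between them. The compounds shown leave open whether 4-hydroxypiperidin-1-yl in place of phenyl changes the result in this assay, and at what concentration any of these compounds would reach half-maximal inhibition.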